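This account rests on a few compounds, and the source may have more. Where it says the series, first, only, none or still open, it means among the compounds named here.

Measured compounds:
compound 1, `Cc1c(-c2ccc(F)cc2)cc(C(=O)NC2CCCCCC2)c(=O)n1Cc1ccc(F)cc1`: in an assay on HEK293 cells for inhibition of Monoacylglycerol lipase ABHD6 (Homo sapiens), read by scintillation counting, with stated times of 30 min and 5 min (on this read-out higher numbers stand for weaker inhibition and lower numbers for stronger inhibition), compound 1 gives > 10000 nM, a limit of the assay rather than a number.
compound 2, `Cc1nc(OCc2ccc(F)cc2)c(C(=O)NC2CCCCCC2)cc1-c1ccc(F)cc1`: in this assay compound 2 gives > 10000 nM, likewise a limit of the assay rather than a number.

Compound 2 therefore stands nowhere definite on the numbers shown: both values sit at the limit of > 10000 nM in this assay, at which 2 of the 2 values shown sit, so neither compound can be placed against the other, and no measured step between them exists. The change to compound 3, `Cc1ccc(C(=O)NC2CCCCCC2)c(OCc2ccc(F)cc2)n1`, is hydrogen in place of 4-fluorophenyl on an aromatic carbon — hydrogen in place of 4-fluorophenyl on an aromatic carbon. Among the measured compounds shown here, no measured pair shows what such a change does in this assay, so the size of the expected step cannot be read from the data. Compound 2 gives only a limit, > 10000 nM, and a move of any size in either direction would most likely stay hidden behind that limit. Compound 3 is therefore expected to give a value near 30000 nM, with a range from 5000 nM to 200000 nM, and most likely to be reported only as a limit again. The step this estimate means is a step that the limit leaves unreadable from compound 2 to compound 3, expected, not measured.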

Compound 3, half-maximal inhibitory concentration: > 10000 nM
Compound 3 was reported as a limit; the forecaster's own chance of this, stated with the estimate: 80%; the middle value is on the limit's open side.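

In this assay compound 3 gives > 10000 nM, a limit of the assay and not a number. Among the compounds shown here, compound 2 also gives only a limit, so no step from compound 2 to compound 3 can be read: the limit of > 10000 nM in this assay, at which 3 of the 3 values shown sit. The compounds shown leave open how far hydrogen in place of 4-fluorophenyl shifts inhibition, and what numerical value any of these compounds would have.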